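The source may hold more compounds than are shown below. What is called first, only, known or untested is meant among the compounds shown, and "the series" means these compounds.

Measured compounds:
- compound 1, `COc1ccc(C2=NOC(COc3ccc(-c4nnnn4-c4cc(OC)c(OC)c(OC)c4)cc3N)C2)cc1OC`: 2520 nM
- compound 2, `COc1ccc(-c2nnnn2-c2cc(OC)c(OC)c(OC)c2)cc1N`: 2630 nM

Both compounds were tested in a functional assay on A549 cells (Homo sapiens) for cytotoxicity, read by MTT assay, with a stated time of 48 h; on this read-out higher numbers stand for weaker inhibition and lower numbers for stronger inhibition. Compound 1 gives 2520 nM, and compound 2 gives 2630 nM. Compound 1 carries the lowest of the two numbers, but the gap to compound 2 lies within the scatter of repeated measurements, so the two values are not told apart. Compound 1 differs from compound 2 by the whole group that carries the five-membered non-aromatic ring with one nitrogen and one oxygen, and the two values show that this addition leaves the read-out in this assay essentially where it was.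

The unmeasured compound 3, `COc1cc(-n2nnnc2-c2ccc(OCC3CC(c4cccc(Cl)c4)=NO3)c(N)c2)cc(OC)c1OC`, departs from compound 1 at the group on the carbon with a double bond to nitrogen of that ring: 3-chlorophenyl in place of 3,4-dimethoxyphenyl on a carbon with a double bond to nitrogen. For the measured compounds named here, no step between measured compounds of this kind is at hand, so the expected step in this assay from compound 1 to compound 3 is small, in either direction, and not clearly beyond the scatter. The expected step is a 1.1-fold lower number from compound 1 to compound 3 (0.06 log units; within the scatter). Compound 3 is therefore estimated at 2200 nM, with a range from 900 nM to 5500 nM.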

Compound 3, half-maximal inhibitory concentration: 1340 nM
Estimate against measurement, compound 3: 1.6-fold (0.22 log units) above; low and high end bracket the measured number.
By their numbers in this assay, from the lowest: compounds 3, 1 and 2 (each within the scatter of the next).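

In this assay, the exchange of 3,4-dimethoxyphenyl for 3-chlorophenyl on the carbon with a double bond to nitrogen gives a 1.9-fold lower number from compound 1 to compound 3 (0.27 log units; within the scatter), so a change of substituents on this aromatic ring, with both oxygens gone and a chlorine present, does not separate the two compounds in this read-out. The whole group carrying the five-membered non-aromatic ring and the 3-chlorophenyl, set in place of a hydrogen atom, gives a 2.0-fold lower number from compound 2 to compound 3 (0.29 log units; within the scatter), so with this aryl group too, the large addition to the smaller compound stays within the scatter, as it did with 3,4-dimethoxyphenyl. No measurement is at hand that bears on why these values lie so close together.

As far as these compounds go, it remains open whether any group on this carbon would move the number beyond the scatter, for instance an unsubstituted phenyl, a 4-chlorophenyl, a pyridine ring or a phenyl carrying a carboxylic acid. The compounds shown also leave open whether the closeness of these values holds in cells other than the A549 line.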